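Moving the Fluorine on a Ring-Bound Phenyl

The source may report more compounds than this note shows. Statements on the series, on what has been measured and on what is new or still open speak of the compounds shown alone.

Of the compounds shown here, three have been measured in a functional assay on SJSA-1 cells (Homo sapiens) for inhibition, read by CCK-8 assay, with a stated time of 72 h, tested at 1 uM; on this read-out lower numbers stand for less inhibition and higher numbers for more inhibition at the one concentration tested (going by the name of the read-out). Compound 1 `COc1ccccc1N1C(=O)C(C)SC1c1cccc(C(=O)NCCCCc2ccccc2)c1` gives 84% in this assay, compound 2 `O=C(NCCCCc1ccccc1)c1cccc(C2SCC(=O)N2c2cccc(F)c2)c1` gives 80%, and compound 3 `COc1ccccc1N1C(=O)CSC1C(=O)NCCCCc1ccccc1` gives 14%. On these numbers compound 2 stands second of three: its value and that of compound 1 lie within the usual scatter of each other, so no order between those two can be claimed, while the gap between compound 2 and compound 3 is far beyond the scatter. Among the measured compounds shown here, no pair among the measured compounds differs in one place only, so no measured step is available to guide the next comparison.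

Compound 4 `O=C(NCCCCc1ccccc1)c1cccc(C2SCC(=O)N2c2ccccc2F)c1` has not yet been measured. It differs from compound 2 in a single way: 2-fluorophenyl in place of 3-fluorophenyl on an amide-type nitrogen in a ring. Nothing in the measured set shows how such a change alters inhibition. The step of a number 2 percentage points lower from compound 2 to compound 4 (within the scatter) is expected to be small, within the scatter, with no clear direction. Compound 4 is accordingly estimated at 78%, in a range from 60% to 92%.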

Compound 4, a percentage reported as inhibition, at one concentration (the size of the read-out at that concentration, not a potency): 80%
The estimate for compound 4 lay 2 percentage points below the measured number, and the stated range covers the measured number.
By their numbers in this assay, from the lowest: compound 3; then compounds 2, 4 and 1 (each within the scatter of the next).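

In this assay, among the compounds shown here, the change to 2-fluorophenyl in place of 3-fluorophenyl on the amide-type nitrogen gives no change at the digits printed from compound 2 to compound 4 (within the scatter) and so provides the first comparison in this set between compounds that differ in one place. For the compounds shown here, at this position and at the one concentration tested, the read-out does not separate the two fluorophenyl groups, which the earlier compounds could not show. No measurement on hand bears on why this step is so small.

Because the read-out comes from one concentration, the compounds shown leave open whether compound 2 and compound 4 would also match at other concentrations. They also leave open how this position would respond to a larger change, such as a plain phenyl or a phenyl carrying an amine or a carboxylic acid.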